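The source may report more compounds than this note shows. Statements on the series, on what has been measured and on what is new or still open speak of the compounds shown alone.

Measured compounds: compound 1 `CCC(=O)Nc1cc(C(=O)Nc2ccc(CN3CCN(C)CC3)c(C(F)(F)F)c2)ccc1OC(C)C` gives 15300 nM in a toxicity assay on Huh-7.5 cells (Homo sapiens) for inhibition, read by MTT assay, with a stated time of 96 h; on this read-out lower numbers stand for higher toxicity in this test and higher numbers for lower toxicity in this test; compound 2 `CCC(=O)Nc1cc(C(=O)Nc2ccc(CN3CCN(C)CC3)c(C(F)(F)F)c2)ccc1OC` gives 35300 nM in this assay; compound 3 `CCC(=O)Nc1cc(C(=O)Nc2ccc(N(C)C)cc2)ccc1OC` gives 171000 nM in this assay.

Compound 2 and compound 3 share part of their structure, but the difference between the two cores is not broken down here. Between compound 2 and compound 1 the change is isopropyl in place of methyl on an oxygen on an aromatic ring, and it made a step of a 2.3-fold lower number from compound 2 to compound 1 (0.36 log units; beyond the scatter). Compound 4 `CCC(=O)Nc1cc(C(=O)Nc2ccc(N(C)C)cc2)ccc1OC(C)C` carries the same change on the core of compound 3: isopropyl in place of methyl on an oxygen on an aromatic ring. The place of the change is the same in both pairs, so the step is expected to be of similar size. Compound 4 is therefore estimated at 75000 nM in this assay, between 35000 nM and 170000 nM. The step that this estimate means is a 2.3-fold lower number from compound 3 to compound 4 (0.36 log units; beyond the scatter). Within the data shown here, it rests on the single earlier example of this change, the step of a 2.3-fold lower number from compound 2 to compound 1 (0.36 log units; beyond the scatter).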

Compound 4, half-maximal cytotoxic concentration: 80600 nM
Compound 4: middle estimate off by 1.1-fold (0.03 log units), on the low side; measured number inside the range.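

In this assay, isopropyl in place of methyl on an oxygen on an aromatic ring gave a 2.1-fold lower number from compound 3 to compound 4 (0.33 log units; beyond the scatter), and the two examples of this change agree: the same change on two cores in this assay, a 2.3-fold lower number (0.36 log units; beyond the scatter) from compound 2 to compound 1 and a 2.1-fold lower number (0.33 log units; beyond the scatter) from compound 3 to compound 4, 1.1-fold (0.04 log units) apart, within the scatter of two such steps. On these two cores, then, the change carried over with much the same size, even though the cores differ elsewhere. Two pairs in one assay do not show that the step would hold on other cores in the series, and they do not explain why the number drops.

The compounds shown leave open whether ethoxy would give a smaller step than isopropoxy, or a longer chain on the oxygen a larger one. They also leave open how a cyclopropyl group would behave in that place.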